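The source may report more compounds than this note shows. Statements on the series, on what has been measured and on what is new or still open speak of the compounds shown alone.

Measured so far:
compound 1 `O=C(O)CCC1=C(c2ccc(Cl)cc2)NC(=S)NC1c1ccccc1O` — 14.7%
compound 2 `O=C(O)CCC1=C(c2ccccc2)NC(=S)NC1c1ccccc1O` — 28.6%
compound 3 `O=C(O)CCC1=C(c2ccc(Cl)cc2)NC(=S)NC1c1ccco1` — 17.9%

All three numbers come from a functional assay on the whole organism (strain Albino) for inhibition, with Rattus norvegicus as the target, with stated times of 1 h and 2 h, at a dose of 20 mg/kg by the oral route; on this read-out higher numbers stand for more inhibition at the one dose given (going by the name of the read-out) and lower numbers for less inhibition. Compound 3 stands second highest of the three. Its nearest neighbour is compound 1, which sits lower by a gap within the scatter, so no order between compound 3 and compound 1 can be read. Compound 2 sits well above compound 3, and that gap is beyond the scatter.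

Compound 4 is `O=C(O)CCC1=C(c2ccccc2)NC(=S)NC1c1ccco1`. It differs from compound 3 in one place: hydrogen in place of chloro on an aromatic carbon.

Among the compounds with values here, one measured step bears directly on this change, the same swap of hydrogen in place of chloro on an aromatic carbon made on the other pair: a number 13.9 percentage points higher from compound 1 to compound 2 (beyond the scatter). That is a modest gain, beyond the scatter. The other measured step, a number 3.2 percentage points higher from compound 1 to compound 3 (within the scatter), only shows that the swap of furan-2-yl for 2-hydroxyphenyl on the saturated ring carbon left the number essentially unchanged, so the furan-bearing pair is not known to behave differently from the hydroxyphenyl-bearing pair. On this single precedent the step is expected to read a number 12.1 percentage points higher from compound 3 to compound 4 (beyond the scatter), upward.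

Compound 4 is therefore estimated at 30%, with a range from 18% to 42%, the width allowing for a single supporting step and the usual scatter.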

Compound 4, a percentage reported as inhibition, in the whole organism at one dose (the size of the read-out at that dose, not a potency): 21.8%
Estimate against measurement, compound 4: 8.2 percentage points above; the range from low to high includes it.
By their numbers in this assay, from the lowest: compounds 1, 3, 4 and 2 (each within the scatter of the next, the first and the last beyond it).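

In this assay, the change from 4-chlorophenyl to phenyl with furan-2-yl on the saturated ring carbon gives a number 3.9 percentage points higher from compound 3 to compound 4 (within the scatter), so the gain beyond the scatter seen with 2-hydroxyphenyl there does not recur beyond the scatter on this second core. The two readings of the change cannot be separated, so these compounds neither establish a general gain from removing the chloro nor show that the outcome depends on the core: the same change on two cores in this assay, a number 13.9 percentage points higher (beyond the scatter) from compound 1 to compound 2 and a number 3.9 percentage points higher (within the scatter) from compound 3 to compound 4, 10 percentage points apart, within the scatter of two such steps The swap of furan-2-yl for 2-hydroxyphenyl can now also be read without the chloro, giving a number 6.8 percentage points lower from compound 2 to compound 4 (within the scatter), and its reading on neither core lies beyond the scatter, nor do the two readings separate: the same change on two cores in this assay, a number 3.2 percentage points higher (within the scatter) from compound 1 to compound 3 and a number 6.8 percentage points lower (within the scatter) from compound 2 to compound 4, 10 percentage points apart, within the scatter of two such steps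

The compounds shown hold only hydrogen and chloro on the aromatic carbon, so it remains open how fluoro, methoxy or an amine at that place would read in this assay. Also open, from the compounds shown here alone, is whether the carboxylic acid is needed, since an ester or an amide at the end of the chain would test this.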